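A Methyl Added to a Series Sitting at the Assay Limit

The source may report more compounds than this note shows. Statements on the series, on what has been measured and on what is new or still open speak of the compounds shown alone.

Measured compounds:
Compound 1, `CN(C)CCC(=O)Nc1cccc(-c2nc3ccccc3s2)c1`. In an ADME assay on HEK293 cells (Homo sapiens) for inhibition, with a stated time of 72 h (on this read-out higher numbers stand for an effect only at larger amounts of compound and lower numbers for an effect already at smaller amounts), compound 1 gives > 25000 nM, which is a limit of the assay rather than a number.
Compound 2, `O=C(Nc1cccc(-c2nc3ccccc3s2)c1)c1cnccc1Cl`. In this assay compound 2 gives > 25000 nM, again a limit.
Compound 3, `O=C(Nc1cccc(-c2nc3ccccc3s2)c1)c1ccc(Cl)nc1Cl`. In this assay compound 3 gives > 25000 nM, also a limit.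

Compound 2 therefore stands where every measured compound stands: at the limit of > 25000 nM in this assay, at which 3 of the 3 values shown sit. Compound 4, `Cc1ccc(-c2nc3ccccc3s2)cc1NC(=O)c1cnccc1Cl`, differs from compound 2 by methyl in place of hydrogen on an aromatic carbon. The measured steps bearing on it are a step that the two limits leave unreadable from compound 1 to compound 2, a step that the two limits leave unreadable from compound 1 to compound 3 and a step that the two limits leave unreadable from compound 2 to compound 3; none of them can be read in size, so no direction beyond the scatter can be expected. Compound 4 is accordingly expected to remain at the limit, with an estimate of 40000 nM (range 12000 nM to 150000 nM). The expected step is a step that the limit leaves unreadable from compound 2 to compound 4.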

Compound 4, half-maximal effective concentration: > 25000 nM
Compound 4 was reported as a limit; the forecaster's own chance of this, stated with the estimate: 85%; the middle value lies beyond the limit too.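

Compound 4 and compound 2 give no step that can be read, because both stand at a limit of the assay: the limit of > 25000 nM in this assay, at which 4 of the 4 values shown sit.

The compounds shown leave open how far past that limit any of them lies, and so whether the methyl changes anything.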